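A few compounds are considered here, and "the series" means these few. Any claim that something is new, unique, unknown or untested is made for them only; others in the source may bear on it.

Of the compounds shown here, three built on one shared core have been tested in a functional assay on the whole organism for antagonist activity, with Mus musculus as the target; on this read-out higher numbers stand for an effect only at larger amounts of compound and lower numbers for an effect already at smaller amounts. Compound 1, `COc1cc(N)c(Cl)cc1NC(=O)C1CCN(CC2CC2)CC1`, carries a cyclopropyl group on a saturated chain carbon bound to an amine nitrogen in a ring. For compound 1 this assay gives only a limit, > 10 mg/kg, and not a number. Compound 2, `COc1cc(N)c(Cl)cc1NC(=O)C1CCN(Cc2cccc(C)c2)CC1`, gives 2.4 mg/kg in this assay. For compound 3, `CCCCCN1CCC(C(=O)Nc2cc(Cl)c(N)cc2OC)CC1`, the read-out is again a limit, > 10 mg/kg. Between these, an at least 4.1-fold lower number from compound 1 to compound 2 (0.61 log units; beyond the scatter), while a step that the two limits leave unreadable from compound 1 to compound 3 and an at least 4.1-fold higher number from compound 2 to compound 3 (0.61 log units; beyond the scatter). Two of the three values therefore rest at the limit of > 10 mg/kg in this assay, at which 2 of the 3 values shown sit.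

Compound 4 is `COc1cc(N)c(Cl)cc1NC(=O)C1CCN(Cc2ccc(O)cc2)CC1`. Compared with compound 1, (4-hydroxyphenyl in place of cyclopropyl on a saturated chain carbon bound to an amine nitrogen in a ring). The step that bears on this change is the one in which an aromatic ring replaced the cyclopropyl group, an at least 4.1-fold lower number from compound 1 to compound 2 (0.61 log units; beyond the scatter); the step to compound 3, which added a chain instead of a ring, stays unreadable. For the measured compounds named here, an aromatic ring on that saturated chain carbon is thus expected to bring the number down, and a step about as large as the one to compound 2 is expected here too, in the downward direction, with the hydroxyl adding some uncertainty. Compound 4 is therefore estimated at 3 mg/kg in this assay, between 1 mg/kg and 10 mg/kg, which would mean an at least 3.3-fold lower number from compound 1 to compound 4 (0.52 log units; beyond the scatter).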

Compound 4, dose for half-maximal effect: > 8 mg/kg
Compound 4 ended at the assay's limit; the forecaster's own chance of this, stated with the estimate: 30%; at least 2.6-fold (0.42 log units) between middle value and limit.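

In this assay compound 4 gives > 8 mg/kg, which is a limit and not a number. An aromatic ring on the saturated chain carbon bound to the ring amine nitrogen is therefore not enough on its own to give a readable dose, since 4-hydroxyphenyl in place of 3-methylphenyl produces an at least 3.3-fold higher number from compound 2 to compound 4 (0.52 log units; beyond the scatter), and what the ring carries matters as well as the ring itself. The steps to compound 4 from compound 1 and from compound 3 join one limit to another and cannot be read, so of the four compounds only compound 2 still has an actual number.

The step from compound 2 changes two things at once, the kind of group on the aromatic ring and where it sits, and the compounds shown do not separate them; 4-methylphenyl and 3-hydroxyphenyl would each change only one, while plain phenyl would show what the bare ring does. From the compounds shown here alone, how far compound 4 lies beyond its limit also stays open, and with it any ranking among compound 1, compound 3 and compound 4.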